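Dimethylamino for neopentylamino on the benzylic carbon of compound 3

A few compounds are considered here, and "the series" means these few. Any claim that something is new, unique, unknown or untested is made for them only; others in the source may bear on it.

Compound 3 `CC(C)(C)CNCc1ccc2c(c1)CCC[C@H]2NC(=O)C[C@@H]1CCCCN1S(=O)(=O)c1cccc(C(F)(F)F)c1` gives 230 nM in a functional assay for inhibition of B1 bradykinin receptor (Homo sapiens), read by calcium flux (on this read-out lower numbers stand for stronger inhibition and higher numbers for weaker inhibition), and has the lowest number among the three measured compounds; compound 2 `COc1ccc(S(=O)(=O)N2CCCC[C@H]2CC(=O)N[C@@H]2CCCc3cc(CNC(C)(C)C)ccc32)cc1` gives 1400 nM and compound 1 `CC(C)(C)NCc1ccc2c(c1)CCC[C@H]2NC(=O)C[C@@H]1CCCCN1S(=O)(=O)c1ccccc1` gives 2400 nM, both higher by steps beyond the scatter. Among the compounds with values here, the one step between compounds that differ in a single place, a 1.7-fold lower number from compound 1 to compound 2 (0.23 log units; within the scatter), concerns the sulfonyl aryl and is within the scatter. Compound 4 `CN(C)Cc1ccc2c(c1)CCC[C@H]2NC(=O)C[C@@H]1CCCCN1S(=O)(=O)c1cccc(C(F)(F)F)c1` differs from compound 3 by dimethylamino in place of neopentylamino on a saturated chain carbon bound to an aromatic carbon. Within the data shown here, none of the measured steps touches the amine on this chain carbon: compounds 1 and 2 carry a tert-butylamino there and differ from compound 3 in two places, so their values show only that the shared core tolerates several amines. Among the measured compounds shown here, with no step bearing on the change, compound 4 is expected to lie near compound 3, with a moderate drift toward a higher number allowed, so a step of a 2.6-fold higher number from compound 3 to compound 4 (0.42 log units; beyond the scatter) is estimated. Compound 4 is therefore expected to give about 600 nM in this assay, between 150 nM and 2500 nM.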

Compound 4, half-maximal inhibitory concentration: 160 nM
The estimate for compound 4 lay 3.8-fold (0.57 log units) above the measured number; the range from low to high includes it.
By their numbers in this assay, from the lowest: compounds 4 and 3 (each within the scatter of the next); then compounds 2 and 1 (each within the scatter of the next).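

In this assay, within the data shown here, the step of a 1.4-fold lower number from compound 3 to compound 4 (0.16 log units; within the scatter) is the first measured change to the amine on this saturated chain carbon bound to an aromatic carbon, and it leaves the two compounds indistinguishable. With the rest of the structure held constant, this pair shows that neopentylamino can give way to dimethylamino, a group with fewer heavy atoms and no hydrogen-bond donor, without a change in the number that exceeds the usual scatter. Nothing shown here bears on why the two amines read alike.

The compounds shown leave open whether dimethylamino would read the same way alongside the sulfonyl aryl of compound 1 or compound 2, since no pair isolates the amine on those sulfonyl aryl groups. They also leave open how far this tolerance extends, for instance to a primary amine, a longer chain on the nitrogen, or a carboxylic acid on the same chain carbon.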